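Aryl swap on a tetrazole series: no shift expected

This account rests on a few compounds, and the source may have more. Where it says the series, first, only, none or still open, it means among the compounds named here.

Three compounds sharing one core have been characterised in an assay on HEK293 cells for activation of Kir3.1/Kir3.2 (Homo sapiens), read by thallium flux; on this read-out lower numbers stand for smaller maximal responses and higher numbers for larger maximal responses. Compound 1, `Cc1cc(NC(=O)Cn2nnc(-c3ccc(F)cc3)n2)n(C2CCCCC2)n1`, reaches 92%. Compound 2, `Cc1cccc(-c2nnn(CC(=O)Nc3cc(C)nn3C3CCCCC3)n2)c1`, reaches 93%. Compound 3, `Cc1cc(NC(=O)Cn2nnc(-c3ccc(C(F)(F)F)cc3)n2)n(C2CCCCC2)n1`, reaches 94%. The three numbers lie close together: the step of a number 2 percentage points higher from compound 1 to compound 3 (within the scatter) is within the scatter, as is the step of a number 1 percentage points higher from compound 2 to compound 3 (within the scatter), and likewise the step of a number 1 percentage points higher from compound 1 to compound 2 (within the scatter). Compound 3 therefore cannot be separated from its two companions on these figures; every exchange of the aryl group made so far has left the maximal response essentially unchanged.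

Compound 4, `Cc1cc(NC(=O)Cn2nnc(-c3ccc(Cl)c(C)c3)n2)n(C2CCCCC2)n1`, continues the same kind of exchange, (4-chloro-3-methylphenyl in place of 4-(trifluoromethyl)phenyl on an aromatic carbon). All three measured steps concern a change of substituent on that same aryl ring, and each stayed within the scatter. Compound 4 is accordingly expected to behave like its predecessors, with a step of a number 2 percentage points lower from compound 3 to compound 4 (within the scatter) and no movement beyond the scatter. Compound 4 is estimated to reach 92% in this assay, with a range from 82% to 102%.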

Compound 4, largest response reached (Emax), in percent of the reference or control that the assay uses: 89%
Compound 4: middle estimate off by 3 percentage points, on the high side; low and high end bracket the measured number.
By their numbers in this assay, from the lowest: compounds 4, 1, 2 and 3 (each within the scatter of the next).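

The position on the aromatic carbon of the five-membered aromatic ring with 4 nitrogen now also accepts an aryl group carrying chlorine and two substituents: in this assay the exchange of 4-(trifluoromethyl)phenyl for 4-chloro-3-methylphenyl gives a number 5 percentage points lower from compound 3 to compound 4 (within the scatter) as its result, with a number 3 percentage points lower from compound 1 to compound 4 (within the scatter) for the exchange of 4-fluorophenyl for the same group. Adding chloro in place of hydrogen on the 3-methylphenyl group, a change at a single place on the ring, gives a number 4 percentage points lower from compound 2 to compound 4 (within the scatter) as its outcome, so the maximal response stays within the scatter across all four aryl groups shown. Nothing at hand offers an explanation for these figures.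

The compounds shown leave open whether a carboxylic acid or an amine on the aryl ring, or a pyridine ring in place of the phenyl ring, would move the maximal response beyond the scatter. Every change shown sits on this one aryl group, so they say nothing about how the response depends on the rest of the shared core.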